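This account rests on a few compounds, and the source may have more. Where it says the series, first, only, none or still open, it means among the compounds named here.

Compound 1 `C/N=C(\S)NCCCCCn1nc(-c2ccccc2)ccc1=O` and compound 2 `C/N=C(/NC#N)NCCCCCn1nc(-c2ccccc2)ccc1=O` share one core and differ only in the group attached to an amine nitrogen. In a functional assay on the whole organism (stomach) with Rattus norvegicus as the target (a higher number here means that more compound is needed for the effect, a lower number that less compound is needed), compound 1 gives 35.3 mg/kg, the lowest of the two numbers recorded, and compound 2 gives 100 mg/kg. Within the data shown here, the one step available, a 2.8-fold higher number from compound 1 to compound 2 (0.45 log units; beyond the scatter), shows that exchanging the sulfur-bearing group for the nitrogen-rich group raised the dose needed.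

Compound 3 `CC/N=C(/NC#N)NCCCn1nc(-c2ccccc2)ccc1=O` is not yet measured. It differs from compound 1 by a group of 8 heavy atoms (4 carbon, 4 nitrogen; no ring) in place of a group of 7 heavy atoms (4 carbon, 2 nitrogen, 1 sulfur; no ring), on a saturated chain carbon, three bonds along the chain from an aromatic nitrogen, so the change again brings in the nitrogen-rich group with a nitrile, and at the same time shortens the saturated chain and lengthens the small alkyl on the nitrogen. Among the measured compounds shown here, only the step from compound 1 to compound 2 bears on this; the chain and alkyl changes have no measured counterpart here. A modest rise in the dose, similar to that step, is expected, as a 2.3-fold higher number from compound 1 to compound 3 (0.36 log units; beyond the scatter). For compound 3 in this assay the estimate is 80 mg/kg, within a range from 30 mg/kg to 220 mg/kg.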

Compound 3, dose for half-maximal effect: 78.3 mg/kg
For compound 3 the middle estimate is 1.0-fold (0.01 log units) above the measured one; the range from low to high includes it.
By their numbers in this assay, from the lowest: compound 1; then compounds 3 and 2 (each within the scatter of the next).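

In this assay the step of a 2.2-fold higher number from compound 1 to compound 3 (0.35 log units; beyond the scatter) shows that the nitrile-bearing group of 8 heavy atoms, on a saturated chain carbon, three bonds along the chain from an aromatic nitrogen, again leaves the number on the higher side of compound 1, even though the chain and the small alkyl on the nitrogen now differ as well. Compound 2 gives 100 mg/kg and compound 3 gives 78.3 mg/kg, two values within the scatter of each other, so both nitrile-bearing compounds stand apart from compound 1 with its sulfur-bearing group. No other measurement is available to explain this rise in the dose needed.

On these data alone, what stays open is how much of the step belongs to the nitrile-bearing group alone and how much to the chain length and the small alkyl, since all of these change together here. Also open, as far as these compounds go, is how a different group in this place, such as a plain amine or a carboxylic acid, or a longer chain, would behave in this assay.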